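Chloro for methoxy on the anilino ring of compound 1

The compounds below may be only part of what the source reports. "The series", "measured", "known", "first", "only" and "open" are said of these compounds alone.

Measured compounds:
compound 1 `CCCSc1nc(Nc2ccc(OC)cc2)c2nc(Nc3ccccc3)sc2n1` — 20700 nM
compound 2 `CCCSc1nc(NC2CC2)c2nc(Nc3ccccc3)sc2n1` — 41700 nM

In a functional assay on NCI-H1650 cells (Homo sapiens) for antiproliferative activity, read by MTT assay, with a stated time of 72 h (a higher number here means a weaker inhibitor, a lower number a stronger inhibitor), compound 1 gives the lower of the two numbers, with compound 2 the nearest neighbour at a 2.0-fold higher number from compound 1 to compound 2 (0.30 log units; within the scatter), a gap within the scatter, so the two cannot be ranked against each other. Compound 3 `CCCSc1nc(Nc2ccc(Cl)cc2)c2nc(Nc3ccccc3)sc2n1` differs from compound 1 in a single place: chloro in place of methoxy on an aromatic carbon. Among the measured compounds shown here, no measured pair shows this same exchange; the only step available, from compound 1 to compound 2, swaps the whole aryl group for a cyclopropyl on that nitrogen and stays within the scatter, so it bears on the new change only loosely, suggesting that this nitrogen substituent has so far moved the number little. With nothing to point to a large shift in either direction, compound 3 is expected to sit close to compound 1, likely again in the weak range. For compound 3 the expected step is therefore a 1.2-fold lower number from compound 1 to compound 3 (0.06 log units; within the scatter). Compound 3 is estimated at 18000 nM, within a range from 6000 nM to 50000 nM.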

Compound 3, half-maximal inhibitory concentration: 12000 nM
The estimate for compound 3 lay 1.5-fold (0.18 log units) above the measured number; measured number inside the range.
By their numbers in this assay, from the lowest: compounds 3, 1 and 2 (each within the scatter of the next, the first and the last beyond it).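

In this assay, chloro in place of methoxy on this aromatic carbon gives a 1.7-fold lower number from compound 1 to compound 3 (0.24 log units; within the scatter), so compound 1 and compound 3 cannot be ranked and this exchange has no effect that can be told from the scatter. The comparison of the two nitrogen substituents adds something new: 4-chlorophenyl in place of cyclopropyl gives a 3.5-fold lower number from compound 2 to compound 3 (0.54 log units; beyond the scatter), a modest step and the only one among those shown that lies beyond the scatter, whereas 4-methoxyphenyl in place of cyclopropyl could not be separated from it. Among the compounds shown here, as compound 1 and compound 3 remain within the scatter of each other, this shows only that the group on this nitrogen can shift the number modestly, and no measurement offered here explains that shift.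

On these data alone, it remains open whether an amine, a carboxylic acid or a trifluoromethyl on this same aromatic carbon would separate clearly from compound 1 and compound 3. As far as these compounds go, it is also open whether a longer chain in place of the propyl group, or a substituent such as fluoro on the other anilino ring, would move the number further from the weak range seen here.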